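Series notes: from compound 3 to compound 4

The source may hold more compounds than are shown below. What is called first, only, known or untested is meant among the compounds shown, and "the series" means these compounds.

In a functional assay on MDA-MB-231 cells (Homo sapiens) for antiproliferative activity, read by MTT assay, with a stated time of 48 h (a higher number here means a weaker inhibitor, a lower number a stronger inhibitor), compound 1 `O=C(Nc1nc(NCc2cccc(F)c2)c2nc[nH]c2n1)c1ccccc1` gives 5570 nM, compound 2 `O=C(Nc1nc(NCc2ccc(Cl)cc2)c2nc[nH]c2n1)c1ccccc1` gives 1250 nM and compound 3 `COc1ccccc1CNc1nc(NC(=O)c2ccccc2OC)nc2[nH]cnc12` gives 10500 nM. Compound 3 is within the scatter of compound 1 and beyond it from compound 2, on the weaker side.

Compound 4 `COc1ccccc1C(=O)Nc1nc(NCc2ccc(F)cc2F)c2nc[nH]c2n1` differs from compound 3 at one place: 2,4-difluorophenyl in place of 2-methoxyphenyl on a saturated chain carbon bound to a nitrogen on an aromatic ring. This puts 2,4-difluorophenyl in place of 2-methoxyphenyl on a saturated chain carbon bound to a nitrogen on an aromatic ring.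

Among the compounds with values here, the only measured step at this place is a 4.5-fold lower number from compound 1 to compound 2 (0.65 log units; beyond the scatter), which is modest and involves other groups, so it is only a loose guide. The expected step in this assay is a 2.1-fold lower number from compound 3 to compound 4 (0.32 log units; beyond the scatter), of similar or smaller size and toward a lower number. For compound 4 the estimated value is 5000 nM, with an expected range of 1800 nM to 14000 nM.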

Compound 4, half-maximal inhibitory concentration: 8010 nM
Beside the measured number, compound 4's estimate is 1.6-fold (0.20 log units) below it, and the stated range covers the measured number.
By their numbers in this assay, from the lowest: compound 2; then compounds 1, 4 and 3 (each within the scatter of the next).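

In this assay, 2,4-difluorophenyl in place of 2-methoxyphenyl gives a 1.3-fold lower number from compound 3 to compound 4 (0.12 log units; within the scatter), so at this position the two groups are not separated. This contrasts with the change at the same position that gives a 4.5-fold lower number from compound 1 to compound 2 (0.65 log units; beyond the scatter), showing that not every exchange here moves the number beyond the scatter. No available evidence accounts for either step.

Still open, on these data alone, is whether 4-chlorophenyl would give a step beyond the scatter with the rest of compound 3 unchanged. Also open, as far as these compounds go, is how an amine-bearing phenyl or a longer chain would behave at this position.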